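Phthalazinone series: a pyrimidinylsulfanyl chain on the ring nitrogen

A few compounds are considered here, and "the series" means these few. Any claim that something is new, unique, unknown or untested is made for them only; others in the source may bear on it.

Measured compounds:
compound 1 `Oc1nnc(-c2cccnc2)c2ccccc12`: 10200 nM
compound 2 `C=CCn1nc(-c2cccnc2)c2ccccc2c1=O`: 2140 nM
compound 3 `CCOC(=O)CCCn1nc(-c2cccnc2)c2ccccc2c1=O`: 10000 nM

The three compounds were tested in a functional assay (trachea) with Cavia porcellus as the target; a higher number here means a weaker inhibitor, a lower number a stronger inhibitor. Compound 1 gives 10200 nM, compound 3 gives 10000 nM, and compound 2 gives 2140 nM, the lowest of the three numbers, with compound 3 its nearest neighbour and compound 1 the furthest, both beyond the scatter.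

Compound 4 `O=c1c2ccccc2c(-c2cccnc2)nn1CCSc1ncccn1` has not yet been measured in this assay. It differs from compound 2 in one place: ((pyrimidin-2-yl)sulfanyl)methyl in place of vinyl on a saturated chain carbon bound to an aromatic nitrogen. Among the measured compounds shown here, the only measured step that bears on this is a 4.7-fold higher number from compound 2 to compound 3 (0.67 log units; beyond the scatter), where 2-(ethoxycarbonyl)ethyl replaced vinyl on the same saturated chain carbon bound to an aromatic nitrogen, and the number rose. Going by these compounds, compound 4 brings in a longer chain carrying a six-membered aromatic ring with two hetero atoms, so a weakening of similar size is expected, while a ring-bearing chain remains untested here. The step of a 2.6-fold higher number from compound 2 to compound 4 (0.41 log units; beyond the scatter) is therefore expected to be a modest rise. Compound 4 is estimated at 5500 nM, within 1500 nM to 20000 nM.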

Compound 4, half-maximal inhibitory concentration: 11000 nM
For compound 4 the middle estimate is 2.0-fold (0.30 log units) below the measured one; measured number inside the range.
By their numbers in this assay, from the lowest: compound 2; then compounds 3, 1 and 4 (each within the scatter of the next).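

In this assay, the second large group on the saturated chain carbon bound to an aromatic nitrogen also moves away from the allyl compound, with a 5.1-fold higher number from compound 2 to compound 4 (0.71 log units; beyond the scatter), so the rise seen with the ester chain is not confined to that one group. The ring-bearing chain and the ester chain cannot be told apart, with a 1.1-fold higher number from compound 3 to compound 4 (0.04 log units; within the scatter), which means that among these compounds a six-membered aromatic ring with 2 hetero atoms at the chain end brings no gain over the ethyl ester. Nothing shown here accounts for the rise at this position.

Going by these compounds, it remains open whether a carboxylic acid or an amine at the chain end would bring the number back towards that of compound 2. On these data alone, it is also open whether a phenyl ring in place of the pyrimidin-2-yl ring would give a similar number.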